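Amide variation on the shared core: compound 2 to compound 3

The source may report more compounds than this note shows. Statements on the series, on what has been measured and on what is new or still open speak of the compounds shown alone.

Measured so far in an assay on HEK293 cells for positive allosteric modulation of metabotropic glutamate receptor 5 (Homo sapiens), read by FLIPR, with a stated time of 1 h; on this read-out lower numbers stand for an effect already at smaller amounts and higher numbers for an effect only at larger amounts of compound:
compound 1 `Cc1cccc(C#Cc2nc3c(s2)C(=O)NCC3)c1`: > 10000 nM
compound 2 `CC(=O)N1CCc2nc(C#Cc3ccccc3)sc2C1`: > 10000 nM

Compound 2 gives > 10000 nM in this assay, which is a limit of the assay and not a number. Compound 1 likewise reaches only a limit, > 10000 nM. Both values sit at the limit of > 10000 nM in this assay, at which 2 of the 2 values shown sit, so nothing measured here separates the two compounds, and compound 2 cannot be placed on a scale; it is simply not active up to where the assay stops.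

Compound 3 `O=C(C1CCC(F)(F)CC1)N1CCc2nc(C#Cc3ccccc3)sc2C1` is the next compound in the series. It differs from compound 2 by 4,4-difluorocyclohexyl in place of methyl on a carbonyl carbon. Among the measured compounds shown here, no step between two measured compounds is available to anchor this change, so any expectation rests only on the fact that compound 2 is inactive to the limit.

The expected step from compound 2 to compound 3 in this assay is an at least 6.6-fold lower number from compound 2 to compound 3 (0.82 log units; beyond the scatter), toward an effect at smaller amounts. For compound 3 the estimate in this assay is 1500 nM, with a range from 200 nM to 10000 nM; a repeat of the limit remains a real possibility.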

Compound 3, half-maximal effective concentration: 70 nM
Beside the measured number, compound 3's estimate is 21-fold (1.33 log units) above it; measured number below the stated range.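

In this assay, the carbonyl carbon on the amide-type nitrogen in a ring proves to be a place where a single change turns a compound with no measurable effect into one with a readable value: 4,4-difluorocyclohexyl in place of methyl gives an at least 140-fold lower number from compound 2 to compound 3 (2.15 log units; beyond the scatter). Compound 2 carries a limit of the assay and not a number, so this step gives only a lower bound on the true size of the change: the limit of > 10000 nM in this assay, at which 2 of the 3 values shown sit. The core shared by compound 2 and compound 3 is therefore not inactive in itself, and the group on this carbonyl carbon decides whether an effect can be read in this series at all.

The entering group differs from methyl in its size, its ring and its fluorine atoms all at once, so the compounds shown do not say which of these features accounts for the step. Plain cyclohexyl, tert-butyl or phenyl on the same carbonyl carbon would begin to separate these features, and a piperidine ring there would show how an amine in that group is tolerated.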